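This account rests on a few compounds, and the source may have more. Where it says the series, first, only, none or still open, it means among the compounds named here.

Working notes on the carbamate series in an ADME assay on a cell-free system (plasma, Homo sapiens), read by HPLC, with a stated time of 120 min, at 37 degrees C; a lower number here means that less of the compound is left, a higher number that more of the compound is left.

Three carbamates of the shared core have numbers in this assay. Compound 1 `C[C@@H]1CN(C(=O)c2nc(Nc3cc(C4CC4)[nH]n3)c3cc(Cl)ccc3n2)CCN1C(=O)OC(C)(C)C` gives 73.7%. Compound 2 `CC(OC(=O)N1CCN(C(=O)c2nc(Nc3cc(C4CC4)[nH]n3)c3cc(Cl)ccc3n2)C[C@H]1C)OC(=O)C(C)(C)C` gives 49.4%. Compound 3 `COC(=O)N1CCN(C(=O)c2nc(Nc3cc(C4CC4)[nH]n3)c3cc(Cl)ccc3n2)C[C@H]1C` gives 84.6%, the highest of the three, its nearest neighbour being compound 1 and the furthest compound 2. Two steps lead to compound 3: a number 10.9 percentage points higher from compound 1 to compound 3 (beyond the scatter), and a number 35.2 percentage points higher from compound 2 to compound 3 (beyond the scatter). The step of a number 24.3 percentage points lower from compound 1 to compound 2 (beyond the scatter) connects the other two.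

The next compound, compound 4 `C[C@@H]1CN(C(=O)c2nc(Nc3cc(C4CC4)[nH]n3)c3cc(Cl)ccc3n2)CCN1C(=O)OCOC(=O)C(C)(C)C`, differs from compound 3 by ((tert-butyl)carbonyl)oxy in place of hydrogen on a saturated chain carbon bound to an oxygen next to a carbonyl group. This gives a carbamate of the same kind as in compound 2, with one carbon fewer on the chain between the two oxygens. The step that bears on it most directly is therefore a number 35.2 percentage points higher from compound 2 to compound 3 (beyond the scatter), read in reverse, together with the smaller step of a number 24.3 percentage points lower from compound 1 to compound 2 (beyond the scatter), which moved in the same direction when an ester-bearing chain entered. On that basis the step from compound 3 to compound 4 is expected to be large and downward, about a number 39.6 percentage points lower from compound 3 to compound 4 (beyond the scatter), in this assay. Compound 4 is accordingly estimated at 45%, with a range from 25% to 65%.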

Compound 4, percent of the compound remaining: 0%
For compound 4 the middle estimate is 45 percentage points above the measured one; measured number below the stated range.
By their numbers in this assay, from the lowest: compound 4; then compound 2; then compound 1; then compound 3.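

In this assay the ester-bearing carbamates separate sharply from the simple ones: a number 84.6 percentage points lower from compound 3 to compound 4 (beyond the scatter), and a number 73.7 percentage points lower from compound 1 to compound 4 (beyond the scatter), so (((tert-butyl)carbonyl)oxy)methyl on the oxygen next to a carbonyl group takes the number to the bottom of the read-out, further than compound 2 had shown. The new pair also shows that this change does not depend on the ester chain alone, since a number 49.4 percentage points lower from compound 2 to compound 4 (beyond the scatter) with only hydrogen in place of methyl on a saturated chain carbon bound to two oxygens next to a carbonyl group, and that single methyl separates a compound with a measurable remainder from one with none. Nothing in the data at hand accounts for this difference.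

Open, from the compounds shown here alone, is how the number responds to other groups on that chain carbon, such as ethyl, isopropyl or a second methyl, and whether acetoxy or another acyloxy group in place of ((tert-butyl)carbonyl)oxy follows the same order. Also open is what compound 4 turns into, as the read-out follows only the compound left and no product, such as a free amine on the shared core, is shown.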